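A few compounds are considered here, and "the series" means these few. Any claim that something is new, unique, unknown or untested is made for them only; others in the source may bear on it.

In a physicochemical assay for solubility, read by HPLC, in phosphate buffer, at pH 6.8 (on this read-out higher numbers stand for higher solubility and lower numbers for lower solubility), three compounds built on a shared core have been measured. Compound 1 `CC(C)C1=C(C(=O)N2[C@H](C)CC[C@H]2C(=O)N2CCN(C)CC2)SC2=N[C@@](C)(c3ccc(Cl)cc3)[C@@H](c3ccc(Cl)cc3)N21` gives 45 ug/mL, compound 2 `CC(=O)N1CCN(C(=O)[C@@H]2CC[C@@H](C)N2C(=O)C2=C(C(C)C)N3C(=N[C@@](C)(c4ccc(Cl)cc4)[C@H]3c3ccc(Cl)cc3)S2)CC1` gives 79 ug/mL, and compound 3 `CC(=O)N1CCN(C(=O)[C@@H]2CC[C@@H](C)N2C(=O)C2=C(C(C)C)N3C(=N[C@@](C)(c4ccc(Cl)cc4)[C@H]3c3ccc(Cl)cc3)S2)C[C@H]1C` gives 72 ug/mL. Compound 3 thus lies within the scatter of both other compounds, and the three numbers support no ranking among them.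

The next compound is compound 4 `CC(=O)N1CCN(C(=O)[C@@H]2CC[C@@H](C)N2C(=O)C2=C(C(C)C)N3C(=N[C@@](C)(c4ccc(Cl)cc4)[C@H]3c3ccc(Cl)cc3)S2)C[C@@H]1C`, and its relation to compound 3 is simple to state: the two compounds have the same atoms and bonds and differ only in configuration as drawn: 1 of 5 stereo elements differ; a stereocentre at a saturated ring carbon is drawn R in compound 3 and S in compound 4. Among the compounds with values here, no measured pair tests a change of configuration alone, so the evidence is only indirect. The closest measured change is a 1.1-fold lower number from compound 2 to compound 3 (0.04 log units; within the scatter), which places a methyl on a saturated ring carbon and lies within the scatter. The two wider changes, a 1.8-fold higher number from compound 1 to compound 2 (0.24 log units; within the scatter) and a 1.6-fold higher number from compound 1 to compound 3 (0.20 log units; within the scatter), also lie within the scatter.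

With none of these three steps beyond the scatter, a change in configuration alone is not expected to produce a real shift in this assay, and no direction can be favoured. The expected result is no change at the digits printed from compound 3 to compound 4 (within the scatter), a step estimated to stay within the scatter. For compound 4 the estimated value is 72 ug/mL, with an expected range from 38 ug/mL to 135 ug/mL.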

Compound 4, solubility: 75 ug/mL
The estimate for compound 4 lay 1.0-fold (0.02 log units) below the measured number; the range from low to high includes it.
By their numbers in this assay, from the lowest: compounds 1, 3, 4 and 2 (each within the scatter of the next).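

In this assay, the step is a 1.0-fold higher number from compound 3 to compound 4 (0.02 log units; within the scatter), the first measured test of configuration alone, and it shows that drawing this saturated ring carbon S rather than R gives no shift that can be told from the scatter. The step can be read as a test of that single change for one reason: the fact that compounds 3 and 4 differ only in the configuration as drawn. The methyl in its S form also behaves as the R form did in the wider comparisons, with a 1.1-fold lower number from compound 2 to compound 4 (0.02 log units; within the scatter) and a 1.7-fold higher number from compound 1 to compound 4 (0.22 log units; within the scatter), so neither configuration of this methyl separates from the compounds without it.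

What remains open is whether anything at this position can move the number beyond the scatter in this assay, as all steps shown so far lie within it, and a hydroxymethyl or a longer chain on the same ring carbon would test that. Equally open, from the compounds shown here alone, is whether a carboxylic acid or a primary amine in place of the acetyl on the ring nitrogen would give a step beyond the scatter, which none of the changes from methyl to acetyl does here.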